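The source may hold more compounds than are shown below. What is called first, only, known or untested is meant among the compounds shown, and "the series" means these compounds.

Working notes on the series. Compound 1 `COc1ccc(-c2c(C#N)c(-c3cccnc3)nc3c2c(-c2cccnc2)nn3-c2ccccc2)cc1` gives 3.73 ug/mL in a functional assay on HepG2 cells (Homo sapiens) for cytotoxicity, read by colorimetric assay; on this read-out higher numbers stand for weaker inhibition and lower numbers for stronger inhibition. Compound 2 `COc1ccc(-c2c(C#N)c(-c3ccccc3)nc3c2c(-c2cccnc2)nn3-c2ccccc2)cc1` carries a phenyl where compound 1 carries a pyridinyl. In this assay compound 2 is recorded as "not active" (no number reported), so no single number places it on the scale; it stands as inactive. Compound 3 `COc1ccc(-c2c(C#N)c(-c3ccc(Cl)cc3)nc3c2c(-c2cccnc2)nn3-c2ccccc2)cc1` is not yet measured. From compound 2 to compound 3 the change is chloro in place of hydrogen on an aromatic carbon. With no measured step of this kind in the set, no size or direction of effect can be drawn from the data. Compound 3 is expected to remain weak in this assay, with an estimated half-maximal inhibitory concentration of 30 ug/mL, in the range 8 ug/mL to 100 ug/mL, and a real chance that only inactivity is reported.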

Compound 3, half-maximal inhibitory concentration: 4 ug/mL
Estimate against measurement, compound 3: 7.5-fold (0.88 log units) above, and the stated range ends above it.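

In this assay this aryl position does not rule out a carbon-only ring: compound 3, with 4-chlorophenyl, gives a number, while compound 2, with plain phenyl, is recorded as inactive, so the step between them cannot be read as a size. Exchanging pyridin-3-yl for 4-chlorophenyl gives a 1.1-fold higher number from compound 1 to compound 3 (0.03 log units; within the scatter) and leaves the two groups indistinguishable on this read-out. Nothing at hand accounts for this result.

On these data alone, whether fluoro, an amine or a carboxylic acid in place of the chloro would also give a number stays open. So does the outcome of moving the chloro elsewhere on this ring.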